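The source may hold more compounds than are shown below. What is called first, only, known or untested is meant among the compounds shown, and "the series" means these compounds.

Compound 1 `CC(=O)N1N=C(c2cccc3ccccc23)CC1c1ccccc1` and compound 3 `O=CCN1N=C(c2ccc3ccccc3c2)CC1c1ccccc1` are built from the same atoms joined differently; the difference between the two cores is not broken down here. In a functional assay on IMR-32 cells (Homo sapiens) for cytotoxicity, read by sulforhodamine B assay, with a stated time of 48 h (a lower number here means a stronger inhibitor, a higher number a weaker inhibitor), compound 1 gives 7760 nM, and compound 3 gives 10000 nM; these two numbers lie within the scatter of each other. Compound 2 `CC(=O)N1N=C(c2cccc3ccccc23)CC1c1ccccc1[N+](=O)[O-]` differs from compound 1 by nitro in place of hydrogen on an aromatic carbon. In this assay compound 2 gives 3980 nM, a step of a 1.9-fold lower number from compound 1 to compound 2 (0.29 log units; within the scatter). Compound 4 `O=CCN1N=C(c2ccc3ccccc3c2)CC1c1cccc([N+](=O)[O-])c1` has not yet been measured; it differs from compound 3 by nitro in place of hydrogen on an aromatic carbon. The two changes are the same kind of change, not the same: in compound 2 the nitro sits ortho to a large group, whereas in compound 4 it sits meta to a large group, and the cores differ. Going by the values given here, the only guide is the step of a 1.9-fold lower number from compound 1 to compound 2 (0.29 log units; within the scatter), which stayed within the scatter. Compound 4 is therefore expected to show a step of about a 1.7-fold lower number from compound 3 to compound 4 (0.22 log units; within the scatter), of a size like the earlier one. Compound 4 is estimated at 6000 nM, within 2500 nM to 14000 nM.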

Compound 4, half-maximal inhibitory concentration: 3280 nM
For compound 4 the middle estimate is 1.8-fold (0.26 log units) above the measured one; measured number inside the range.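

In this assay, nitro in place of hydrogen on the aromatic ring gives a 3.0-fold lower number from compound 3 to compound 4 (0.48 log units; beyond the scatter), a modest step. Set beside the same change on the other core, the two steps cannot be told apart in size: the same change on two cores in this assay, a 1.9-fold lower number (0.29 log units; within the scatter) from compound 1 to compound 2 and a 3.0-fold lower number (0.48 log units; beyond the scatter) from compound 3 to compound 4, 1.6-fold (0.19 log units) apart, within the scatter of two such steps. This shows that the change goes the same way on both cores and that its size holds across them within the scatter, but it rests on two pairs only, one of whose steps, a 1.9-fold lower number from compound 1 to compound 2 (0.29 log units; within the scatter), itself stays within the scatter, and the nitro does not stand at the same place in the two pairs, so place and core cannot be separated.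

The compounds shown leave open whether nitro at one and the same place on both cores would give matching steps. They also leave open whether an amine or a carboxylic acid in place of the nitro, or a longer chain in place of the one carrying the carbonyl, would shift the number in the same way.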